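This account rests on a few compounds, and the source may have more. Where it says the series, first, only, none or still open, it means among the compounds named here.

Measured compounds:
- compound 1 `c1ccc(-c2cn3ccnc3c(-c3ccc4ncn(C5CCCCC5)c4c3)n2)cc1`: 36.5%
- compound 2 `O=Cc1ccc(-c2cn3ccnc3c(-c3ccc4ncn(C5CCCCC5)c4c3)n2)cc1`: 56.5%

In a functional assay on SK-MEL-5 cells (Homo sapiens) for inhibition, read by sulforhodamine B assay, with a stated time of 48 h, tested at 10 uM (a higher number here means more inhibition at the concentration tested (going by the name of the read-out), a lower number less inhibition), compound 2 gives the higher of the two numbers shown, with compound 1 beneath it by a number 20 percentage points higher from compound 1 to compound 2 (beyond the scatter). Compound 3 `Fc1ccccc1-c1cn2ccnc2c(-c2ccc3ncn(C4CCCCC4)c3c2)n1` differs from compound 2 by 2-fluorophenyl in place of 4-formylphenyl on an aromatic carbon. Among the compounds with values here, the only measured step that bears on this change is the one from compound 1 to compound 2, which added the formyl group and was a number 20 percentage points higher from compound 1 to compound 2 (beyond the scatter); compound 3 gives up that formyl group while taking on a fluorine whose effect is not measured. Compound 3 is therefore expected to fall back toward compound 1, by a number 16.5 percentage points lower from compound 2 to compound 3 (beyond the scatter), in this assay, to about 40% within 25% to 58%.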

Compound 3, a percentage reported as inhibition, at one concentration (the size of the read-out at that concentration, not a potency): 6.5%
Beside the measured number, compound 3's estimate is 33.5 percentage points above it; measured number outside the range, below it.
By their numbers in this assay, from the lowest: compound 3; then compound 1; then compound 2.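

In this assay, 2-fluorophenyl in place of 4-formylphenyl gives a number 50 percentage points lower from compound 2 to compound 3 (beyond the scatter), and fluoro in place of hydrogen gives a number 30 percentage points lower from compound 1 to compound 3 (beyond the scatter). A substituent on this aromatic ring can therefore lower the number as well as raise it, and compound 3 falls past the unsubstituted compound 1 rather than back to it. No measurement at hand accounts for this drop. On these data alone, it remains open whether the fall belongs to fluorine itself or to where it sits on the ring, and how an amine or a carboxylic acid in the formyl group's place would read.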